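The source may hold more compounds than are shown below. What is called first, only, known or untested is meant among the compounds shown, and "the series" means these compounds.

Compound 3 `N#C/N=C(/NCCCCc1c[nH]cn1)NCCCc1ccccc1` stands level with compound 1 `N#C/N=C(\NCCCc1ccccc1)NCCCc1c[nH]cn1` in an in vitro functional assay on Sf9 cells for antagonist activity at histamine H2 receptor (Homo sapiens); a higher number here means a more potent compound, by a factor of ten per unit of this negative logarithm, a lower number a less potent compound: compound 3 gives 5.25 and compound 1 gives 5.25, while compound 2 `N#C/N=C(\NCCCCc1ccccc1)NCCCc1c[nH]cn1` gives 5.03. The step of no change at the digits printed from compound 1 to compound 3 (within the scatter) and the step of a number 0.22 log units lower from compound 1 to compound 2 (within the scatter) both lie within the scatter. Compound 4 `N#C/N=C(\NCCCCc1ccccc1)NCCCCc1c[nH]cn1` differs from compound 3 by benzyl in place of phenyl on a saturated chain carbon, three bonds along the chain from an amine nitrogen. Within the data shown here, the one step that bears on this is the same change made on compound 1, which gave a number 0.22 log units lower from compound 1 to compound 2 (within the scatter); no step beyond the scatter is therefore expected in this assay, and the expected step is a number 0.20 log units lower from compound 3 to compound 4 (within the scatter). For compound 4 the estimate in this assay is 5.05, within a range from 4.65 to 5.45.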

Compound 4, negative logarithm of the antagonist equilibrium constant: 5.03
Compound 4: the middle estimate sits 0.02 log units above what was measured, and the stated range covers the measured number.
By their numbers in this assay, from the lowest: compounds 2, 4, 1 and 3 (each within the scatter of the next).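

In this assay the change to benzyl in place of phenyl now reads on a second core, a number 0.22 log units lower from compound 3 to compound 4 (within the scatter), and it matches the earlier step: the same change on two cores in this assay, a number 0.22 log units lower (within the scatter) from compound 1 to compound 2 and a number 0.22 log units lower (within the scatter) from compound 3 to compound 4, 0.00 log units apart, within the scatter of two such steps. The change to (1H-imidazol-4-yl)methyl in place of 1H-imidazol-4-yl also reads a second time, no change at the digits printed from compound 2 to compound 4 (within the scatter): the same change on two cores in this assay, no change at the digits printed (within the scatter) from compound 1 to compound 3 and no change at the digits printed (within the scatter) from compound 2 to compound 4, 0.00 log units apart, within the scatter of two such steps. Neither change moves the number beyond the scatter on either core.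

Still open, from the compounds shown here alone, is whether a longer chain at either end, or an amine on the phenyl ring, gives a step beyond the scatter.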